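Swapping thiophen-3-yl for 4-hydroxyphenyl in compound 3

The compounds below may be only part of what the source reports. "The series", "measured", "known", "first", "only" and "open" are said of these compounds alone.

Measured in a functional assay on HCT-15 cells (Homo sapiens) for cytotoxicity, read by ELISA, with a stated time of 2 days; a higher number here means a weaker inhibitor, a lower number a stronger inhibitor:
- compound 1 `Oc1ccccc1-c1cc(-c2ccccc2)cc(-c2ccccc2O)n1`: > 50000 nM (a limit)
- compound 2 `Oc1cccc(-c2cc(-c3ccccc3)cc(-c3ccsc3)n2)c1`: 7660 nM
- compound 3 `Oc1ccc(-c2cc(-c3ccccc3)cc(-c3ccsc3)n2)cc1`: 1100 nM

Of the two true numbers, compound 3 has the lower (1100 nM). Compound 4 `Oc1ccc(-c2cc(-c3ccccc3)cc(-c3ccc(O)cc3)n2)cc1` carries 4-hydroxyphenyl in place of thiophen-3-yl, next to the ring nitrogen (4-hydroxyphenyl in place of thiophen-3-yl on an aromatic carbon). Among the measured compounds shown here, no measured step makes this swap. The nearest guide is a modest step beyond the scatter, with 4-hydroxyphenyl in place of 3-hydroxyphenyl (a 7.0-fold lower number from compound 2 to compound 3 (0.84 log units; beyond the scatter)). Compound 1, which also lacks thiophen-3-yl, stays at a limit of the assay (> 50000 nM). That limit argues for caution, so a modest rise in this assay is expected, with an estimated step (a 2.3-fold higher number from compound 3 to compound 4 (0.36 log units; beyond the scatter)). For compound 4 the estimated value is 2500 nM (expected range 500 nM to 12000 nM).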

Compound 4, half-maximal inhibitory concentration: 3000 nM
Compound 4: the middle estimate sits 1.2-fold (0.08 log units) below what was measured; measured number inside the range.
By their numbers in this assay, from the lowest: compound 3; then compound 4; then compound 2. At a limit, above all of these: compound 1.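

In this assay, the position next to the ring nitrogen accepts a six-membered 4-hydroxyphenyl ring in place of the five-membered thiophen-3-yl ring, with a 2.7-fold higher number from compound 3 to compound 4 (0.44 log units; beyond the scatter). Thiophen-3-yl is therefore not required for a true number in the low micromolar region, although compound 3 keeps the lower number of this pair. Nothing measured here explains the modest rise.

The compounds shown leave open what a plain phenyl, a furan-3-yl or a 4-aminophenyl group would do at this position. Without them, the share of the hydroxyl group in this step cannot be separated from that of the ring swap.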